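A few compounds are considered here, and "the series" means these few. Any claim that something is new, unique, unknown or untested is made for them only; others in the source may bear on it.

Measured compounds:
compound 1 `N/C(=N\C(=O)CCc1c[nH]c2ccccc12)NCCCc1c[nH]cn1`, a functional assay on cardiac atrium for agonist activity at histamine H2 receptor (Cavia porcellus); a higher number here means that more compound is needed for the effect, a lower number that less compound is needed: 77.6 nM
compound 2 `CCC(=O)/N=C(\N)NCCCc1c[nH]cn1`, this assay: 302 nM

For the measured compounds named here, compound 2 gives the higher of the two numbers measured so far. Its nearest neighbour is compound 1, whose value in this assay is lower by a margin that lies beyond the usual scatter. Going by the values given here, no step between compounds differing in one place has been measured, so no directly comparable step size is available.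

Compound 3 `CC(=O)/N=C(\N)NCCCc1c[nH]cn1` has not yet been measured in this assay. It differs from compound 2 by hydrogen in place of methyl on a saturated chain carbon bound to a carbonyl carbon, propanoyl becoming acetyl.

On the two values available, the shorter acyl chain of compound 3 is expected to give a somewhat higher number than compound 2, a step of a 2.0-fold higher number from compound 2 to compound 3 (0.30 log units; within the scatter), though a result within the scatter would not be surprising. Compound 3 is thus estimated at 600 nM, with a range from 200 nM to 2000 nM.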

Compound 3, half-maximal effective concentration: 813 nM
Compound 3: middle estimate off by 1.4-fold (0.13 log units), on the low side, and the stated range covers the measured number.
By their numbers in this assay, from the lowest: compound 1; then compound 2; then compound 3.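

In this assay the change from propanoyl to acetyl gives a 2.7-fold higher number from compound 2 to compound 3 (0.43 log units; beyond the scatter) for the loss of one carbon from the acyl chain. For the compounds shown here, this is the only single-place step available, and it shows that this saturated chain carbon bound to a carbonyl carbon is not indifferent to its substituent: hydrogen in place of methyl means that more compound is needed for the effect. No available measurement bears on the reason for this step.

A single step does not establish a trend with acyl chain length, so a longer chain such as butanoyl could continue this direction, level off or reverse it. As far as these compounds go, it also remains open how an amine or a carboxylic acid at this position would compare with methyl and hydrogen.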